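Bromo to chloro on the aryl of compound 1

The source may report more compounds than this note shows. Statements on the series, on what has been measured and on what is new or still open speak of the compounds shown alone.

Measured compounds:
- compound 1, `COc1ccc2cc(C(C)c3nnc4n3N=C(c3ccc(Br)cc3)CS4)ccc2c1`: 11500 nM
- compound 2, `CC(c1ccc(-c2ccccc2)c(F)c1)c1nnc2n1N=C(c1ccc(C(F)(F)F)cc1)CS2`: 4300 nM
- compound 3, `COc1ccc(C2=Nn3c(nnc3C(C)c3ccc(-c4ccccc4)c(F)c3)SC2)cc1`: 2600 nM

In a functional assay on MCF7 cells (Homo sapiens) for inhibition, read by sulforhodamine B assay, with a stated time of 72 h (on this read-out higher numbers stand for weaker inhibition and lower numbers for stronger inhibition), compound 1 gives 11500 nM, the highest number of the three, which on this read-out is the weakest inhibition; compound 2 gives 4300 nM and compound 3 gives 2600 nM, both beyond the scatter from compound 1. Compound 4, `COc1ccc2cc(C(C)c3nnc4n3N=C(c3ccc(Cl)cc3)CS4)ccc2c1`, differs from compound 1 by chloro in place of bromo on an aromatic carbon.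

Within the data shown here, no measured step touches this halogen swap. Among the measured compounds shown here, the single step on record, a 1.7-fold lower number from compound 2 to compound 3 (0.22 log units; within the scatter), concerns a different group on the same kind of aryl and stays within the scatter. With nothing pointing either way, the expected step in this assay is none beyond the scatter, a 1.0-fold higher number from compound 1 to compound 4 (0.02 log units; within the scatter). Compound 4 is therefore estimated at 12000 nM, with a range from 5000 nM to 30000 nM.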

Compound 4, half-maximal inhibitory concentration: 10100 nM
Beside the measured number, compound 4's estimate is 1.2-fold (0.07 log units) above it, and the stated range covers the measured number.
By their numbers in this assay, from the lowest: compounds 3 and 2 (each within the scatter of the next); then compounds 4 and 1 (each within the scatter of the next).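

In this assay, the change from 4-bromophenyl to 4-chlorophenyl gives a 1.1-fold lower number from compound 1 to compound 4 (0.06 log units; within the scatter). At this position, para to a large group, chloro and bromo therefore cannot be told apart on the core of compound 1; the earlier step, a 1.7-fold lower number from compound 2 to compound 3 (0.22 log units; within the scatter), involved methoxy and trifluoromethyl on a different core and did not test a halogen swap. Nothing available bears on this result. From the compounds shown here alone, whether an amine or a carboxylic acid at this position would move the number beyond the scatter remains open. Also open, going by these compounds, is whether chloro and bromo would read alike on the core of compound 2.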